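The source may report more compounds than this note shows. Statements on the series, on what has been measured and on what is new or still open speak of the compounds shown alone.

Compound 1 `CC(C)Oc1cc(Oc2ccc(S(C)(=O)=O)cc2)cc(-c2cccc(=O)[nH]2)c1`: 11000 nM
Compound 2 `CC(C)Oc1cc(Oc2ccc(S(C)(=O)=O)cc2)cc(-c2cncc(=O)[nH]2)c1`: 118000 nM
Compound 3 `CC(C)Oc1cc(Oc2ccc(S(C)(=O)=O)cc2)cc(-c2nccc(=O)[nH]2)c1`: 25000 nM

In a physicochemical assay for solubility, in phosphate buffer, measured as kinetic solubility, with a stated time of 24 h, at pH 6.5 (on this read-out lower numbers stand for lower solubility and higher numbers for higher solubility), compound 2 stands highest of the three at 118000 nM. Compound 4 `CC(C)Oc1cc(Oc2ccc(S(C)(=O)=O)cc2)cc(-c2ncc(Cl)c(=O)[nH]2)c1` differs from it as follows: a group of 8 heavy atoms (4 carbon, 2 nitrogen, 1 oxygen, 1 chlorine; one six-membered aromatic ring with 2 hetero atoms) in place of a group of 7 heavy atoms (4 carbon, 2 nitrogen, 1 oxygen; one six-membered aromatic ring with 2 hetero atoms), on an aromatic carbon.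

Three measured exchanges at this place bear on the change. They are an 11-fold higher number from compound 1 to compound 2 (1.03 log units; beyond the scatter), a 2.3-fold higher number from compound 1 to compound 3 (0.36 log units; beyond the scatter) and a 4.7-fold lower number from compound 2 to compound 3 (0.67 log units; beyond the scatter), so they range from modest to large. The closest guide is the modest drop of a 4.7-fold lower number from compound 2 to compound 3 (0.67 log units; beyond the scatter). Within the data shown here, no measured step adds a chlorine. A large step to a lower number is expected in this assay, estimated as a 9.8-fold lower number from compound 2 to compound 4 (0.99 log units; beyond the scatter). Compound 4 is expected at 12000 nM, with an estimated range of 3000 nM to 45000 nM.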

Compound 4, solubility: 24000 nM
The estimate for compound 4 lay 2.0-fold (0.30 log units) below the measured number; the measured number falls inside the stated range.
By their numbers in this assay, from the lowest: compound 1; then compounds 4 and 3 (each within the scatter of the next); then compound 2.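

In this assay, chloro in place of hydrogen on an aromatic carbon can now be read directly, and it falls within the scatter (a 1.0-fold lower number from compound 3 to compound 4 (0.02 log units; within the scatter)). The chlorine-bearing group therefore stands with compound 3, well short of compound 2 (a 4.9-fold lower number from compound 2 to compound 4 (0.69 log units; beyond the scatter)) but still beyond compound 1 (a 2.2-fold higher number from compound 1 to compound 4 (0.34 log units; beyond the scatter)). No measurement shown accounts for these steps.

Going by these compounds, whether a methyl, a nitrile or an amine in place of the chloro would read the same remains open. So does the effect of chloro on the groups of compound 1 and compound 2.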